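The compounds below may be only part of what the source reports. "The series", "measured", "known", "first", "only" and "open" are said of these compounds alone.

The measured compounds and their values in a functional assay on NCI-H460 cells (Homo sapiens) for inhibition, read by sulforhodamine B assay, with a stated time of 48 h; on this read-out higher numbers stand for weaker inhibition of growth and lower numbers for stronger inhibition of growth:

Compound 1 `O=C(Nc1cccc(-n2cc(-c3ccncc3)c(-c3ccc(Cl)c(O)c3)n2)c1)Nc1cccc(C(F)(F)F)c1` gives 29000 nM.
Compound 2 `COc1cc(-c2nn(-c3cccc(NC(=O)Nc4cc(C(F)(F)F)cc(C(F)(F)F)c4)c3)cc2-c2ccncc2)ccc1Cl` gives 1870 nM.
Compound 3 `COc1cc(-c2nn(-c3cccc(NC(=O)Nc4cccc(C(F)(F)F)c4)c3)cc2-c2ccncc2)ccc1Cl` gives 3530 nM.

Among these three, compound 2 has the lowest number, that is, the strongest inhibition of growth. Its nearest neighbour is compound 3: a 1.9-fold higher number from compound 2 to compound 3 (0.28 log units; within the scatter), a gap that lies within the scatter, so no real order between the two can be claimed. Compound 1 sits much further away, with a number beyond the scatter from compound 2.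

Compound 4 `O=C(Nc1cccc(-n2cc(-c3ccncc3)c(-c3ccc(Cl)c(O)c3)n2)c1)Nc1cc(C(F)(F)F)cc(C(F)(F)F)c1` has not yet been measured. It differs from compound 2 in one place: hydrogen in place of methyl on an oxygen on an aromatic ring.

Among the compounds with values here, one measured step bears directly on this change, read in the opposite direction: an 8.2-fold lower number from compound 1 to compound 3 (0.91 log units; beyond the scatter). There, adding the methyl to the oxygen lowered the number well beyond the scatter, so removing the methyl is expected to raise it by a step of similar size. Compound 1 carries the same hydroxy group, and its value offers a second anchor; the difference between compound 1 and compound 4 is the same as that between compound 3 and compound 2, which stayed within the scatter.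

Taken together, compound 4 is expected to show a clearly higher number than compound 2, with an 8.6-fold higher number from compound 2 to compound 4 (0.93 log units; beyond the scatter). The estimate for compound 4 is 16000 nM, within a range from 6000 nM to 40000 nM.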

Compound 4, concentration for total growth inhibition: 1480 nM
The estimate for compound 4 lay 11-fold (1.03 log units) above the measured number; measured number below the stated range.
By their numbers in this assay, from the lowest: compounds 4, 2 and 3 (each within the scatter of the next, the first and the last beyond it); then compound 1.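

In this assay the swap of methoxy for hydroxy turns out not to carry a fixed cost: on the core of compound 2 it gives a 1.3-fold lower number from compound 2 to compound 4 (0.10 log units; within the scatter) and so leaves no readable difference, and the large rise seen earlier on the core of compound 3 does not repeat here: the same change on two cores in this assay, an 8.2-fold lower number (0.91 log units; beyond the scatter) from compound 1 to compound 3 and a 1.3-fold higher number (0.10 log units; within the scatter) from compound 4 to compound 2, 10-fold (1.02 log units) apart, beyond the scatter of two such steps. The extra trifluoromethyl behaves in the same uneven way, since it gives a 20-fold lower number from compound 1 to compound 4 (1.29 log units; beyond the scatter) when the hydroxy is present, yet has no readable effect when the methoxy is present: the same change on two cores in this assay, a 1.9-fold higher number (0.28 log units; within the scatter) from compound 2 to compound 3 and a 20-fold higher number (1.29 log units; beyond the scatter) from compound 4 to compound 1, 10-fold (1.02 log units) apart, beyond the scatter of two such steps. The two changes therefore cannot be scored separately, and among these four compounds only compound 1, which has the hydroxy without the extra trifluoromethyl, stands apart from the rest.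

On that oxygen the compounds shown carry only hydrogen or methyl, so it remains open how a longer chain such as ethyl, or an amine in place of the oxygen, would fare with and without the extra trifluoromethyl. The numbers also cannot tell why the two changes depend on each other, and a single pair of cores is too little to say how general this is.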